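Trading a large side group for isopropyl

The source may report more compounds than this note shows. Statements on the series, on what has been measured and on what is new or still open speak of the compounds shown alone.

Compound 1 `c1cnc2c(c1)CCC[C@@H]2N(CC1CC1)C[C@H]1Cc2c(cccc2N2CCNCC2)CN1`: 82.1%
Compound 2 `FC1(F)CCC(CN(C[C@H]2Cc3c(cccc3N3CCNCC3)CN2)[C@H]2CCCc3cccnc32)CC1`: 68.6%
Compound 3 `CN(C[C@H]1Cc2c(cccc2N2CCN3CCC[C@@H]3C2)CN1)[C@H]1CCCc2cccnc21`: 52.2%

These numbers come from an ADME assay on microsomes from liver (Homo sapiens) for metabolic stability, read by LC-MS, with a stated time of 10 min; on this read-out lower numbers stand for a less stable compound and higher numbers for a more stable compound. Compound 2 gives 68.6%, the second highest of the three, lying below compound 1 and above compound 3, with both gaps beyond the usual scatter.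

The next compound to be measured is compound 4 `CC(C)N(C[C@H]1Cc2c(cccc2N2CCNCC2)CN1)[C@H]1CCCc2cccnc21`. It keeps the core of compound 2 and changes one group: isopropyl in place of (4,4-difluorocyclohexyl)methyl on an amine nitrogen. In words, isopropyl takes the place of (4,4-difluorocyclohexyl)methyl on an amine nitrogen.

Among the measured compounds shown here, one measured step bears on this change, a number 13.5 percentage points lower from compound 1 to compound 2 (beyond the scatter). This modest step brings in the 4,4-difluorocyclohexyl group in place of cyclopropyl, and compound 4 removes that same group, so read backwards it points to a higher number. The match is only partial, since isopropyl is not the side group of compound 1. Compound 3 differs from compound 2 in more than one place and gives no clean comparison.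

In this assay, a rise of similar or somewhat smaller size is therefore expected, an estimated a number 8.4 percentage points higher from compound 2 to compound 4 (within the scatter). The expected value for compound 4 is 77%, with an estimated range from 63% to 90%.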

Compound 4, percent of the compound remaining: 75%
Compound 4: middle estimate off by 2 percentage points, on the high side; the measured number falls inside the stated range.
By their numbers in this assay, from the lowest: compound 3; then compounds 2, 4 and 1 (each within the scatter of the next, the first and the last beyond it).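

In this assay, putting isopropyl, with 3 heavy atoms and no ring, in place of (4,4-difluorocyclohexyl)methyl, with 9 heavy atoms and a six-membered ring, gives a small step (a number 6.4 percentage points higher from compound 2 to compound 4 (within the scatter)), and putting it in place of cyclopropylmethyl also gives a small step (a number 7.1 percentage points lower from compound 1 to compound 4 (within the scatter)). Isopropyl on this amine nitrogen therefore cannot be told apart from either larger group, even though those two groups do stand apart from each other (a number 13.5 percentage points lower from compound 1 to compound 2 (beyond the scatter)), so among these three compounds a group without a ring serves about as well here as the two groups with rings. No measurement shown offers a reason for these numbers.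

The compounds shown leave open how a plain cyclohexylmethyl group, a straight propyl chain or a chain ending in a carboxylic acid would read on this amine nitrogen. Going by these compounds, compound 3 carries methyl there but also differs elsewhere in the structure, so the effect of methyl alone at this place remains unknown.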